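This account rests on a few compounds, and the source may have more. Where it says the series, first, only, none or still open, it means among the compounds named here.

Compound 1 `C/C(=N\OC(Cc1ccc(OCc2ccc3ccccc3n2)cc1)C1CCCCC1)C(=O)O`: 50 nM
Compound 2 `O=C(O)/C=N/OC(c1ccc(OCc2nc3ccccc3s2)cc1)C1CCCCC1`: 60 nM
Compound 3 `O=C(O)/C=N/OC(c1ccc(OCc2nc3ccccc3s2)cc1Cl)C1CCCCC1`: 28 nM

In a functional assay for inhibition of Polyunsaturated fatty acid 5-lipoxygenase (Homo sapiens) (a lower number here means a stronger inhibitor, a higher number a weaker inhibitor), compound 3 gives the lowest of the three numbers; its gap to compound 2 is beyond the scatter, whereas compound 1 sits within the scatter of it, so no order between compound 1 and compound 3 can be claimed. Among the compounds with values here, the only measured single-point step is a 2.1-fold lower number from compound 2 to compound 3 (0.33 log units; beyond the scatter), a modest one. Compound 4 `O=C(O)/C=N/OC(c1ccc(OCc2nc3cc(F)ccc3s2)cc1Cl)C1CCCCC1` differs from compound 3 by fluoro in place of hydrogen on an aromatic carbon. Within the data shown here, no measured step bears directly on this ring, and the halogen step from compound 2 to compound 3 serves only as a loose analogy. The change is therefore expected to be small, at most a modest shift in either direction. Compound 4 is estimated at 25 nM in this assay, range 10 nM to 60 nM, a step of a 1.1-fold lower number from compound 3 to compound 4 (0.05 log units; within the scatter).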

Compound 4, half-maximal inhibitory concentration: 14 nM
The estimate for compound 4 lay 1.8-fold (0.25 log units) above the measured number; measured number inside the range.
By their numbers in this assay, from the lowest: compounds 4, 3, 1 and 2 (each within the scatter of the next, the first and the last beyond it).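

In this assay, the change from 1,3-benzothiazol-2-yl to 5-fluoro-1,3-benzothiazol-2-yl gives a 2.0-fold lower number from compound 3 to compound 4 (0.30 log units; within the scatter), so fluoro is tolerated at this position, but no gain can be claimed. Within the data shown here, this is the first reading on this ring, since the earlier step, a 2.1-fold lower number from compound 2 to compound 3 (0.33 log units; beyond the scatter), placed chloro elsewhere in the molecule. Nothing measured here points to a cause for the step.

Open, from the compounds shown here alone, is whether methoxy, trifluoromethyl or an amine on this carbon would be tolerated as well. Also open, going by these compounds, is whether fluoro here would give a similar step in the absence of the chloro of compound 3.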